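Swapping Methoxy for Methylsulfanyl on a Weak Growth Inhibitor

The compounds below may be only part of what the source reports. "The series", "measured", "known", "first", "only" and "open" are said of these compounds alone.

Compound 1 `COc1ccc(CNc2nc([Se]C)nc3ccccc23)cc1` is a weak growth inhibitor in a functional assay on HT-29 cells (Homo sapiens) for cytotoxicity, read by MTT assay, with a stated time of 72 h (on this read-out higher numbers stand for weaker inhibition of growth and lower numbers for stronger inhibition of growth), where compound 1 gives 73600 nM, the higher of the two numbers recorded. Its nearest neighbour is compound 3 `COc1ccc(CNc2nc(SC)nc3ccccc23)cc1`, which gives 70200 nM in this assay; the step is a 1.0-fold lower number from compound 1 to compound 3 (0.02 log units; within the scatter). For compound 2 `CCCCC[Se]c1nc([Se]CCCCC)c2ccccc2n1` this assay reports only a limit, > 100000 nM, not a number. Compound 4 `CSc1ccc(CNc2nc([Se]C)nc3ccccc23)cc1` differs from compound 1 by methylsulfanyl in place of methoxy on an aromatic carbon. Among the compounds with values here, the one measured step, a 1.0-fold lower number from compound 1 to compound 3 (0.02 log units; within the scatter), exchanged atoms elsewhere on the shared core and stayed within the scatter, so no step beyond the scatter is expected here either: the expected step is a 1.0-fold higher number from compound 1 to compound 4 (0.01 log units; within the scatter). Compound 4 is therefore estimated at 75000 nM, in a range from 35000 nM to 150000 nM.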

Compound 4, concentration for 50% growth inhibition: 72700 nM
For compound 4 the middle estimate is 1.0-fold (0.01 log units) above the measured one; low and high end bracket the measured number.
By their numbers in this assay, from the lowest: compounds 3, 4 and 1 (each within the scatter of the next). At a limit, above all of these: compound 2.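

Within the data shown here, the step, a 1.0-fold lower number from compound 1 to compound 4 (0.01 log units; within the scatter), adds something the earlier compounds could not show: at this place, para to a large group, an oxygen-linked methyl group and a sulfur-linked one give numbers within the scatter of each other in this assay. Among these compounds, the earlier step changed only the atom on the shared core, so this is the first reading at this end of the molecule. Nothing measured here gives a reason for this result.

As far as these compounds go, whether an amine, a carboxylic acid or a longer chain at this place would shift the number remains open.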